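The source may report more compounds than this note shows. Statements on the series, on what has been measured and on what is new or still open speak of the compounds shown alone.

In a functional assay on A549 cells (Homo sapiens) for inhibition, read by MTT assay, with a stated time of 72 h (a lower number here means a stronger inhibitor, a higher number a weaker inhibitor), compound 1 `Cc1ccc(-c2nnc(SCCCN3CCN(c4nc5ccccc5o4)CC3)o2)cc1` gives 106000 nM and compound 2 `c1ccc(-c2nnc(SCCCN3CCN(c4nc5ccccc5o4)CC3)o2)cc1` gives 108000 nM, so the two stand level. Compound 3 `O=C(NCc1nnc(SCCCN2CCN(c3nc4ccccc4o3)CC2)o1)c1ccccc1` differs from compound 2 as follows: benzamidomethyl in place of phenyl on an aromatic carbon. In short, it has benzamidomethyl in place of phenyl on an aromatic carbon. Among the measured compounds shown here, the only measured step, a 1.0-fold higher number from compound 1 to compound 2 (0.01 log units; within the scatter), puts hydrogen in place of methyl, a quite different exchange, so it is a weak guide and no clear shift beyond the scatter is expected. The expected change is a 1.2-fold lower number from compound 2 to compound 3 (0.08 log units; within the scatter). For compound 3 the estimate is 90000 nM, with a range of 35000 nM to 200000 nM.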

Compound 3, half-maximal inhibitory concentration: 102000 nM
Beside the measured number, compound 3's estimate is 1.1-fold (0.05 log units) below it, and the stated range covers the measured number.
By their numbers in this assay, from the lowest: compounds 3, 1 and 2 (each within the scatter of the next).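

On the aromatic carbon of the five-membered ring, the much larger benzamidomethyl, which brings a hydrogen-bond donor and acceptor that phenyl lacks, leaves the number in this assay level (a 1.1-fold lower number from compound 2 to compound 3 (0.02 log units; within the scatter)). The comparison with the 4-methylphenyl group reads the same way (a 1.0-fold lower number from compound 1 to compound 3 (0.02 log units; within the scatter)). So far, three quite different groups at this position give numbers within the scatter of one another, and no measurement here offers an explanation. Still open, from the compounds shown here alone, is whether a group of another kind at this carbon, such as a carboxylic acid or an aminomethyl group, would move the number beyond the scatter.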